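The source may hold more compounds than are shown below. What is called first, only, known or untested is meant among the compounds shown, and "the series" means these compounds.

Series notes, core of compound 1 `CCC(=O)N1CC2CC(C1)N2` with an amide carbonyl bearing the variable group. In an assay on SH-EP1 cells for displacement of a labelled ligand from Neuronal acetylcholine receptor; alpha4/beta2 (Homo sapiens), read by scintillation counting (on this read-out higher numbers stand for weaker inhibition and lower numbers for stronger inhibition), compound 1 gives 6 nM, compound 2 `O=C([C@@H]1C[C@@H]1F)N1CC2CC(C1)N2` gives 1.7 nM and compound 3 `C[C@@H]1C[C@@H]1C(=O)N1CC2CC(C1)N2` gives 22 nM. Compound 3 stands highest of the three, with a 3.7-fold higher number from compound 1 to compound 3 (0.56 log units; beyond the scatter) and a 13-fold higher number from compound 2 to compound 3 (1.11 log units; beyond the scatter).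

Compound 4 `C[C@@H]1C[C@H]1C(=O)N1CC2CC(C1)N2` differs from compound 3 only as follows: the two compounds have the same atoms and bonds; at least one stereo element is drawn with a configuration in one of them and without one in the other: 1 of 4 stereo elements differ; a stereocentre at a saturated ring carbon is drawn S in compound 3 and R in compound 4. Within the data shown here, no measured step involves a change of configuration alone; the steps from compound 1 and compound 2 to compound 3 swap whole groups and bear only indirectly. No direction can therefore be argued from the data, and a step within the scatter is expected, no change at the digits printed from compound 3 to compound 4 (within the scatter). Compound 4 is expected to give 22 nM in this assay, within 5 nM to 90 nM.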

Compound 4, inhibition constant: 1 nM
Compound 4: middle estimate off by 22-fold (1.34 log units), on the high side; the measured number lies below the stated range.
By their numbers in this assay, from the lowest: compounds 4 and 2 (each within the scatter of the next); then compound 1; then compound 3.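

In this assay, configuration alone at this saturated ring carbon makes a large difference, a 22-fold lower number from compound 3 to compound 4 (1.34 log units; beyond the scatter), so the 2-methylcyclopropyl group cannot be judged apart from its configuration. In the configuration of compound 4, this group improves on ethyl, a 6.0-fold lower number from compound 1 to compound 4 (0.78 log units; beyond the scatter), while the comparison with 2-fluorocyclopropyl gives a 1.7-fold lower number from compound 2 to compound 4 (0.23 log units; within the scatter), which does not separate the two groups. The reading of the stereo pair carries one caveat: the fact that one of compounds 3 and 4 is drawn with a defined configuration and the other without, at the place where they differ.

Going by these compounds, whether the 2-fluorocyclopropyl group depends on configuration in the same way stays open. So does the outcome for a cyclobutyl or 2-hydroxymethylcyclopropyl group on the carbonyl carbon.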